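A Chlorine Moved Around the Benzyl Ring

The source may report more compounds than this note shows. Statements on the series, on what has been measured and on what is new or still open speak of the compounds shown alone.

Three compounds share one sulfonamide core. Compound 1 `O=S(=O)(NCCCNCc1ccccc1Cl)c1cc(C(F)(F)F)cc(C(F)(F)F)c1` gives 20000 nM in a functional assay on HT-29 cells (Homo sapiens) for inhibition, read by MTT assay, with a stated time of 72 h; a higher number here means a weaker inhibitor of growth, a lower number a stronger inhibitor of growth. Compound 2 `O=S(=O)(NCCCCNCc1ccc(Br)cc1)c1cc(C(F)(F)F)cc(C(F)(F)F)c1` gives 1600 nM, and compound 3 `O=S(=O)(NCCCNCc1ccc(C(F)(F)F)cc1)c1cc(C(F)(F)F)cc(C(F)(F)F)c1` gives 2900 nM. Compound 3 thus lies well apart from compound 1, as a 6.9-fold lower number from compound 1 to compound 3 (0.84 log units; beyond the scatter) shows, while its gap to compound 2 is within the usual scatter. Compound 4 `O=S(=O)(NCCCNCc1cccc(Cl)c1)c1cc(C(F)(F)F)cc(C(F)(F)F)c1` differs from compound 3 by 3-chlorophenyl in place of 4-(trifluoromethyl)phenyl on a saturated chain carbon bound to an amine nitrogen. Among the measured compounds shown here, two measured steps bear on this: a 6.9-fold lower number from compound 1 to compound 3 (0.84 log units; beyond the scatter) and a 13-fold lower number from compound 1 to compound 2 (1.10 log units; beyond the scatter) both show a chlorine or other group moved away from the position in compound 1 strengthening inhibition. For the measured compounds named here, no compound carries a 3-chlorophenyl, so the step back is uncertain. The expected change is a 1.7-fold higher number from compound 3 to compound 4 (0.24 log units; within the scatter). Compound 4 is estimated at 5000 nM, ranging from 1500 nM to 17000 nM.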

Compound 4, concentration for 50% growth inhibition: 14000 nM
For compound 4 the middle estimate is 2.8-fold (0.45 log units) below the measured one, within the range that was stated.
By their numbers in this assay, from the lowest: compounds 2 and 3 (each within the scatter of the next); then compounds 4 and 1 (each within the scatter of the next).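

The 2-chlorophenyl and 3-chlorophenyl groups cannot be told apart here (a 1.4-fold lower number from compound 1 to compound 4 (0.15 log units; within the scatter)). Replacing 4-(trifluoromethyl)phenyl with 3-chlorophenyl, by contrast, gives weaker growth inhibition (a 4.8-fold higher number from compound 3 to compound 4 (0.68 log units; beyond the scatter)), and the step from the 4-bromobenzyl compound with its longer chain points the same way (an 8.8-fold higher number from compound 2 to compound 4 (0.94 log units; beyond the scatter)). Nothing available gives a reason for these steps. As far as these compounds go, it remains open whether a 4-chlorophenyl would behave like the 4-(trifluoromethyl)phenyl of compound 3, and how an amine or a carboxylic acid on this ring would fare.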